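The compounds below may be only part of what the source reports. "The series", "measured", "known", "first", "only" and "open" are said of these compounds alone.

Compound 2 `COC(=O)/C=C/c1cccc(N(Cc2ccc(/C=C/c3cccc(Cl)c3)cc2)C(=O)C2CCCCC2)c1` carries a cyclohexyl group on a carbonyl carbon and a 3-chlorophenyl group on a double-bonded chain carbon. In an assay on isolated protein with Bile acid receptor (Homo sapiens) as the target (on this read-out higher numbers stand for an effect only at larger amounts of compound and lower numbers for an effect already at smaller amounts), compound 2 gives 166 nM. Within the data shown here, its only measured neighbour is compound 1 `COC(=O)/C=C/c1cccc(N(Cc2ccc(/C=C/c3c(Cl)cccc3Cl)cc2)C(=O)C2CCCCC2)c1`, which in this assay gives 151 nM; the single measured step, a 1.1-fold higher number from compound 1 to compound 2 (0.04 log units; within the scatter), alters the chlorinated ring and leaves the carbonyl substituent untouched. Compound 3 `COC(=O)/C=C/c1cccc(N(Cc2ccc(/C=C/c3cccc(Cl)c3)cc2)C(=O)C(C)C)c1` differs from compound 2 by isopropyl in place of cyclohexyl on a carbonyl carbon. Among the measured compounds shown here, no measured step touches this part of the molecule, so the one step available offers no direct guide to the size or direction of the change. With nothing to lean on, a modest weakening is the expectation, a 1.8-fold higher number from compound 2 to compound 3 (0.26 log units; within the scatter), with a wide allowance for either outcome. For compound 3 in this assay the estimated value is 300 nM, within a range from 120 nM to 800 nM.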

Compound 3, half-maximal effective concentration: 162 nM
Compound 3: middle estimate off by 1.9-fold (0.27 log units), on the high side; the measured number falls inside the stated range.
By their numbers in this assay, from the lowest: compounds 1, 3 and 2 (each within the scatter of the next).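

Among these compounds, this is the first measured change at the carbonyl carbon, where the earlier step altered only the chlorinated ring. In this assay the replacement of cyclohexyl by isopropyl gives a 1.0-fold lower number from compound 2 to compound 3 (0.01 log units; within the scatter). So on this core, cyclohexyl, with 6 heavy atoms and one ring, and isopropyl, with 3 heavy atoms and no ring, cannot be told apart by this read-out, and the ring is not needed to keep the number in this range. No available evidence explains this result.

From the compounds shown here alone, whether a methyl group, a phenyl group or an amine on the carbonyl carbon would fit the same picture remains open. Going by these compounds, it is also open whether isopropyl would read the same alongside the 2,6-dichlorophenyl group of compound 1.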